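The source may report more compounds than this note shows. Statements on the series, on what has been measured and on what is new or still open speak of the compounds shown alone.

Compound 1 `Oc1cccc(-c2ccc3c(O)cccc3c2)c1` gives 32% in an assay for binding affinity to 17-beta-hydroxysteroid dehydrogenase type 2 (Homo sapiens), with a stated time of 20 min, tested at 1 uM; a lower number here means less inhibition, a higher number more inhibition at the concentration tested (going by the name of the read-out). Compound 2 `Oc1cccc2cc(-c3ccc(F)cc3)ccc12` does not give a number in this assay but only the limit of the assay, < 10%. Compound 3 `Oc1cccc2cc(-c3cncnc3)ccc12` also sits at that limit, with < 10% in this assay. Compound 2 therefore stands at the floor of what this assay can report, sharing (the limit of < 10% in this assay, at which 2 of the 3 values shown sit). The change to compound 4 `CNC(=O)c1ccc(-c2ccc3c(O)cccc3c2)cc1` is methylcarbamoyl in place of fluoro on an aromatic carbon. Going by the values given here, no measured pair shows this same change. Because compound 1 with its hydroxyl and 32% shows that an inhibition of that size is reached in this assay, a step upward beyond the usual scatter is expected, a number at least 12 percentage points higher from compound 2 to compound 4 (beyond the scatter). Compound 4 is estimated to give about 22% in this assay, with a range from 5% to 42%.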

Compound 4, a percentage reported as inhibition, at one concentration (the size of the read-out at that concentration, not a potency): 13%
Compound 4: the middle estimate sits 9 percentage points above what was measured, and the stated range covers the measured number.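

In this assay, methylcarbamoyl in place of fluoro, para to a large group, gives a number at least 3 percentage points higher from compound 2 to compound 4 (that floor lies within the scatter). Compound 2 has only a limit, < 10%. The new group thus gives a readable number at this position, but a real gain from the change cannot be claimed, and the evidence stops at the floor: the limit of < 10% in this assay, at which 2 of the 4 values shown sit.

On these data alone, whether an amine or a carboxylic acid at this position would rise beyond the scatter remains open. So does whether the amide hydrogen matters, which a dimethylcarbamoyl group could test.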